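Swapping Methyl for Methoxyphenyl on a Shared Core

The source may hold more compounds than are shown below. What is called first, only, known or untested is meant among the compounds shown, and "the series" means these compounds.

Compound 2 `CCOC(=O)c1cc(-c2cccc(OC(=O)NC3CCCCC3)c2)nn1C` and compound 1 `NC(=O)c1cc(-c2cccc(OC(=O)NC3CCCCC3)c2)n(-c2ccccc2)n1` share most of their structure and differ in the groups carried on their five-membered ring. For the measured compounds named here, in an assay on isolated protein for inhibition of Fatty-acid amide hydrolase 1 (Homo sapiens), read by fluorescence, with a stated time of 30 min (a higher number here means a weaker inhibitor, a lower number a stronger inhibitor), compound 2 gives 227 nM, the higher of the two numbers known so far, while compound 1 gives 169 nM; that gap lies within the scatter. Compound 3 `CCOC(=O)c1cc(-c2cccc(OC(=O)NC3CCCCC3)c2)nn1-c1ccc(OC)cc1` is not yet measured and shows (4-methoxyphenyl in place of methyl on an aromatic nitrogen). Going by the values given here, no measured pair isolates this change, so only a modest step, if any, is expected. Compound 3 is expected at 150 nM, within a range from 50 nM to 500 nM. The expected step is a 1.5-fold lower number from compound 2 to compound 3 (0.18 log units; within the scatter), which may stay inside the scatter.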

Compound 3, half-maximal inhibitory concentration: 407 nM
Compound 3: the middle estimate sits 2.7-fold (0.43 log units) below what was measured, and the stated range covers the measured number.
By their numbers in this assay, from the lowest: compounds 1, 2 and 3 (each within the scatter of the next, the first and the last beyond it).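

On the aromatic nitrogen, 4-methoxyphenyl in place of methyl gives a 1.8-fold higher number from compound 2 to compound 3 (0.25 log units; within the scatter) in this assay. For the compounds shown here, this is the first measured pair that isolates this position, and it shows that a group with an added six-membered aromatic ring and more heavy atoms leaves the number within the scatter of that of compound 2. Nothing available explains the step.

On these data alone, whether a propyl chain on this nitrogen would give a similar number remains open. So does the effect of a carboxylic acid in place of the ethoxycarbonyl group.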